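A few compounds are considered here, and "the series" means these few. Any claim that something is new, unique, unknown or untested is made for them only; others in the source may bear on it.

This set concerns an ADME assay on CHO cells (Cricetulus griseus) for cytotoxicity, read by MTT assay; on this read-out higher numbers stand for weaker inhibition and lower numbers for stronger inhibition. Compound 1 `CCN(CC)CC(Cn1cncn1)NCc1ccccc1` gives only a limit of the assay, > 300000 nM. Compound 3 `CCN(CC)CC(CN(CC)CC)NCc1ccccc1` likewise gives only a limit, > 300000 nM. For compound 2 `CCN(CC)CC(Cn1cc(C)c(=O)[nH]c1=O)NCc1ccc(OC)cc1` the result is "not determined" (no result reported). Compound 3 therefore stands at the limit where two of the three results sit (the limit of > 300000 nM in this assay, at which 2 of the 3 values shown sit), with no single number beside it. Within the data shown here, the one step between measured compounds, a step that the two limits leave unreadable from compound 1 to compound 3, has no readable size; both of its ends are limits. Compound 4 `CCN(CC)CC(CN(CC)CC)NCc1ccc(OC)cc1` differs from compound 3 by methoxy in place of hydrogen on an aromatic carbon. No measured step touches a methoxy on an aromatic carbon, so nothing shown bears directly on this change, and no step beyond the usual scatter is expected. Compound 3 itself sits at a limit > 300000 nM, so compound 4 is expected to return a limit as well rather than a number. The expected step is a number no higher from compound 3 to compound 4 (the limit leaves the size open). Compound 4 is estimated at 300000 nM, with a range from 100000 nM to 1000000 nM.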

Compound 4, half-maximal inhibitory concentration: 170000 nM
Estimate against measurement, compound 4: 1.8-fold (0.25 log units) above; the range from low to high includes it.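

Among these compounds, compound 4 is the first compound here to give a number in this assay rather than a limit, so this position on the aromatic ring is the first place in the set where a change can be given a direction. Methoxy in place of hydrogen on an aromatic carbon, para to a large group, gives an at least 1.7-fold lower number from compound 3 to compound 4 (0.24 log units; that floor lies within the scatter). Only a floor is known for this step, and since that floor lies within the scatter, it does not by itself establish a real change; the two other compounds with values remain at the limit: the limit of > 300000 nM in this assay, at which 2 of the 4 values shown sit.

The compounds shown leave open whether ethoxy or a chlorine atom on the same aromatic carbon would behave like methoxy. They also leave open how far the true step from hydrogen to methoxy extends beyond its floor.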